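The source may hold more compounds than are shown below. What is called first, only, known or untested is meant among the compounds shown, and "the series" means these compounds.

Measured so far:
compound 1 `N/C(=N\NC(=S)N1CCOCC1)c1ccccn1`: 82.8%
compound 2 `Cc1cccc(/C(N)=N/NC(=S)N2CCSCC2)n1`: 85.3%

Both numbers come from a functional assay on HeLa cells (Homo sapiens) for cytotoxicity, read by MTT assay, with a stated time of 72 h, tested at 30 uM; a higher number here means more inhibition of growth at the concentration tested, a lower number less inhibition of growth. Compound 2 has the higher of the two, but its gap to compound 1 lies within the scatter, so the two values show no difference that can be trusted. Compound 3 `Cc1cccc(/C(N)=N/NC(=S)N2CCOCC2)n1` keeps the core of compound 2 and carries morpholin-4-yl in place of thiomorpholin-4-yl on a thiocarbonyl carbon. For the measured compounds named here, no measured pair isolates this exchange, and the two values already in hand give no hint of a large effect, so no step beyond the scatter is expected in this assay. The expected step is a number 2.3 percentage points lower from compound 2 to compound 3 (within the scatter). Compound 3 is therefore estimated at 83%, in the range 70% to 92%.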

Compound 3, percent growth inhibition at one concentration: 86.9%
For compound 3 the middle estimate is 3.9 percentage points below the measured one; the measured number falls inside the stated range.
By their numbers in this assay, from the lowest: compounds 1, 2 and 3 (each within the scatter of the next).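

In this assay, morpholin-4-yl in place of thiomorpholin-4-yl on a thiocarbonyl carbon gives a number 1.6 percentage points higher from compound 2 to compound 3 (within the scatter) and so no difference that can be trusted. Methyl in place of hydrogen on an aromatic carbon gives a number 4.1 percentage points higher from compound 1 to compound 3 (within the scatter) and likewise shows no readable effect, now with the morpholin-4-yl group held the same. Nothing available offers an explanation for either result.

Still open, on these data alone, is whether piperidin-1-yl or dimethylamino on the thiocarbonyl carbon would shift the number. As far as these compounds go, a carboxylic acid or a longer chain in place of the methyl is equally open.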